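The source may report more compounds than this note shows. Statements on the series, on what has been measured and on what is new or still open speak of the compounds shown alone.

Working notes. Compound 1 `O=C1CSC(=O)N1C[C@H]1CN(c2ccc(-n3cc(-c4ccccn4)cn3)c(F)c2)C(=O)O1` gives 26900 nM in a physicochemical assay for solubility, read by HPLC, with a stated time of 24 h; on this read-out higher numbers stand for higher solubility and lower numbers for lower solubility. Compound 2 `O=C(NC[C@H]1CN(c2ccc(-n3cc(-c4ccccn4)cn3)c(F)c2)C(=O)O1)C(F)F` gives 29900 nM in this assay. Within the data shown here, the single step in hand, a 1.1-fold higher number from compound 1 to compound 2 (0.05 log units; within the scatter), is within the scatter, so compound 2 stands alongside compound 1 with no separation that the numbers can support.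

Compound 3 `CONC(=O)[C@H]1CN(c2ccc(-n3cc(-c4ccccn4)cn3)c(F)c2)C(=O)O1` differs from compound 2 by methoxycarbamoyl in place of (((difluoromethyl)carbonyl)amino)methyl on a saturated ring carbon. Among the measured compounds shown here, only the step from compound 1 to compound 2 bears on this change, and only loosely, since it exchanged groups on the chain carbon rather than on the ring carbon; it showed no movement beyond the scatter. With nothing in the series pointing to a shift, compound 3 is expected to give a number close to that of compound 2, the estimated step being a 1.0-fold higher number from compound 2 to compound 3 (0.00 log units; within the scatter). The estimate for compound 3 in this assay is 30000 nM, with a range from 15000 nM to 60000 nM.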

Compound 3, solubility: 78100 nM
For compound 3 the middle estimate is 2.6-fold (0.42 log units) below the measured one; the measured number lies above the stated range.
By their numbers in this assay, from the lowest: compounds 1 and 2 (each within the scatter of the next); then compound 3.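

In this assay the exchange on the saturated ring carbon next to the ring oxygen gives the first separation in the series (a 2.6-fold higher number from compound 2 to compound 3 (0.42 log units; beyond the scatter)), whereas the earlier step between the two side chains stayed within the scatter. The comparison with the other side chain points the same way (a 2.9-fold higher number from compound 1 to compound 3 (0.46 log units; beyond the scatter)), so at this ring carbon methoxycarbamoyl stands clear of both (((difluoromethyl)carbonyl)amino)methyl and (2,4-dioxo-1,3-thiazolidin-3-yl)methyl. No measurement in hand accounts for this rise.

From the compounds shown here alone, it remains open whether a plain carboxamide, a carboxylic acid or a longer chain ending in methoxycarbamoyl would give a similar number at this ring carbon. Going by these compounds, it also remains open whether the methoxy group itself matters, as methoxycarbamoyl appears here only in compound 3, on the shared core.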